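The source may report more compounds than this note shows. Statements on the series, on what has been measured and on what is new or still open speak of the compounds shown alone.

Compound 1 `COc1ccc2c(=O)c(/C=C/C(=O)Nc3cc(C)ccc3C)coc2c1` gives 15500 nM in a functional assay on A549 cells (Homo sapiens) for inhibition, read by MTT assay, with a stated time of 48 h; on this read-out lower numbers stand for stronger inhibition and higher numbers for weaker inhibition. Compound 3 `COc1ccc(NC(=O)/C=C/c2coc3cc(O)ccc3c2=O)cc1` gives 12800 nM in this assay, a value within the usual scatter of that of compound 1, so no order between the two can be claimed. Compound 2 `O=C(/C=C/c1coc2cc(O)ccc2c1=O)NCc1ccc(F)cc1` reaches only a limit of the assay, > 100000 nM. The single measured step among these three, an at least 7.8-fold lower number from compound 2 to compound 3 (0.89 log units; beyond the scatter), rests on the limit of > 100000 nM in this assay, at which 1 of the 3 values shown sits, and concerns the group on the amide-type nitrogen rather than a substituent on that ring. Compound 4 `COc1ccc2c(=O)c(/C=C/C(=O)Nc3ccccc3C)coc2c1` differs from compound 1 by hydrogen in place of methyl on an aromatic carbon. For the measured compounds named here, no measured step bears on this change, and the measured compounds offer no guidance on a lone methyl. Compound 4 is therefore expected to show a 1.0-fold lower number from compound 1 to compound 4 (0.01 log units; within the scatter), nothing beyond the scatter. Compound 4 is estimated at 15000 nM, between 6000 nM and 40000 nM.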

Compound 4, half-maximal inhibitory concentration: 23400 nM
Compound 4: middle estimate off by 1.6-fold (0.19 log units), on the low side, within the range that was stated.
By their numbers in this assay, from the lowest: compounds 3, 1 and 4 (each within the scatter of the next). At a limit, above all of these: compound 2.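

Going from the 2,5-dimethylphenyl group to the 2-methylphenyl group gives the first measured step at this position in this assay, a 1.5-fold higher number from compound 1 to compound 4 (0.18 log units; within the scatter), and this step stays within the scatter. The methyl on this aromatic carbon, meta to a large group, therefore has no effect that can be claimed in this series. Nothing on hand accounts for the step. From the compounds shown here alone, it remains open whether another group at this position, such as an amine, a carboxylic acid or a longer chain, would move the number beyond the scatter.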